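Quinoxaline dioxide analogues: from butyl to 4-methoxyphenyl

A few compounds are considered here, and "the series" means these few. Any claim that something is new, unique, unknown or untested is made for them only; others in the source may bear on it.

Within the data shown here, compound 3 `CCCCCOCNc1n[n+]([O-])c2ccccc2[n+]1[O-]` gives 39500 nM in a functional assay on KB cells (Homo sapiens) for cytotoxicity, read by MTT assay, with a stated time of 72 h (a lower number here means a stronger inhibitor, a higher number a weaker inhibitor), the highest of the three numbers known. Its nearest neighbour is compound 2 `COc1ccc2c(c1)[n+]([O-])nc(NCOCc1ccccc1)[n+]2[O-]`, which gives 18100 nM in this assay, and the furthest is compound 1 `COc1ccc2c(c1)[n+]([O-])nc(NCOC(C)c1ccccc1)[n+]2[O-]`, which gives 12400 nM in this assay. Among the measured compounds shown here, the one measured step, a 1.5-fold higher number from compound 1 to compound 2 (0.16 log units; within the scatter), lies within the scatter and does not touch the position changed here. Compound 4 `COc1ccc(COCNc2n[n+]([O-])c3ccccc3[n+]2[O-])cc1` differs from compound 3 by 4-methoxyphenyl in place of butyl on a saturated chain carbon bound to an oxygen on a saturated carbon. For the measured compounds named here, no measured pair changes the group at this place, so the expectation rests on the comparison alone: compound 2 and compound 1 carry an aromatic ring on this chain carbon and both show lower numbers than compound 3, though they also differ from compound 3 elsewhere. Compound 4 is therefore expected to give a somewhat lower number than compound 3, the step of a 2.0-fold lower number from compound 3 to compound 4 (0.30 log units; within the scatter) being estimated with wide uncertainty. Compound 4 is estimated at 20000 nM in this assay, with a range from 9000 nM to 45000 nM.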

Compound 4, half-maximal inhibitory concentration: 14200 nM
Compound 4: the middle estimate sits 1.4-fold (0.15 log units) above what was measured; the range from low to high includes it.
By their numbers in this assay, from the lowest: compounds 1, 4 and 2 (each within the scatter of the next); then compound 3.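

In this assay, 4-methoxyphenyl in place of butyl on a saturated chain carbon bound to an oxygen on a saturated carbon gives a 2.8-fold lower number from compound 3 to compound 4 (0.44 log units; beyond the scatter). Among these compounds, this modest step is the first direct reading at this place, as the earlier compounds differed from compound 3 elsewhere as well, and it shows that the group here can shift the number beyond the scatter on an otherwise unchanged core. No measurement shown accounts for the step.

This single pair cannot separate the contribution of the aromatic ring from that of its methoxy group, and an unsubstituted phenyl would be needed to tell them apart. On these data alone, how an amine or a longer chain at this place would read also remains open, as does whether the step would carry over to the core of compound 2.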